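Amino for chloro on the purine-type core of compound 2

This account rests on a few compounds, and the source may have more. Where it says the series, first, only, none or still open, it means among the compounds named here.

Three compounds with a chloromethyl-substituted benzyl group on a shared two-ring core have been measured in a functional assay on UO-31 cells (Homo sapiens) for cytotoxicity, read by sulforhodamine B assay, with a stated time of 48 h; on this read-out lower numbers stand for stronger inhibition of growth and higher numbers for weaker inhibition of growth. Compound 1 `ClCc1ccc(Cn2cnc3c(Cl)ncnc32)cc1` gives 2080 nM. Compound 2 `ClCc1ccccc1Cn1cnc2c(Cl)nc(Cl)nc21` gives 420 nM, and compound 3 `ClCc1cccc(Cn2cnc3nc(Cl)nc(Cl)c32)c1` gives 17400 nM. On these numbers compound 2 stands lowest of the three: compound 1 is nearest, with a number beyond the scatter above it, and compound 3 is furthest, far above it.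

Compound 4 `Nc1nc(Cl)c2ncn(Cc3ccccc3CCl)c2n1` has not yet been measured in this assay. It differs from compound 2 in one place: amino in place of chloro on an aromatic carbon, that is, an amino group in place of a chloro group on an aromatic carbon, between two ring nitrogen atoms, meta to a chloro group, meta to a fused ring and para to a fused ring. No measured pair in this set shows this exchange, so there is no shown step to lean on; the remaining compounds vary only in where the chloromethyl group sits and in how many chloro groups the core carries.

Given the absence of a comparable step, compound 4 is expected to lie somewhat above compound 2 in this assay, with a step of a 2.9-fold higher number from compound 2 to compound 4 (0.46 log units; beyond the scatter) that may fall within or just beyond the scatter. The estimate for compound 4 is 1200 nM, within a range from 300 nM to 5000 nM.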

Compound 4, concentration for 50% growth inhibition: 15500 nM
Estimate against measurement, compound 4: 13-fold (1.11 log units) below; measured number outside the range, above it.
By their numbers in this assay, from the lowest: compound 2; then compound 1; then compounds 4 and 3 (each within the scatter of the next).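

In this assay the chloro group on the aromatic carbon between two ring nitrogen atoms proves far from interchangeable: amino in its place brings a 37-fold higher number from compound 2 to compound 4 (1.57 log units; beyond the scatter) and leaves growth inhibition much weaker, a large step well beyond the scatter. Within the data shown here, the earlier compounds differ from one another in more than one place, so they could not isolate this position; this single exchange gives the first direct reading of it. The exchange replaces one heavy atom with one heavy atom and adds a hydrogen-bond donor and a hydrogen-bond acceptor, but no measurement here explains the size of the step.

From the compounds shown here alone, it remains open whether this step belongs to amino alone or would also appear with another group on this carbon, such as methoxy, methylamino or a thiol. The compounds shown also leave open whether the same exchange would produce a step of similar size at the other chloro group on the core, or with the chloromethyl group elsewhere on the benzyl ring.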